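This account rests on a few compounds, and the source may have more. Where it says the series, first, only, none or still open, it means among the compounds named here.

In a functional assay on MDA-MB-231 cells (Homo sapiens) for cytotoxicity, read by MTT assay, with a stated time of 24 h (on this read-out lower numbers stand for stronger inhibition and higher numbers for weaker inhibition), compound 1 `C[C@H]1O[C@]1(C)C(=O)C[C@@H]1[C@@]2(C)[C@@H](O)CCC(C)(C)[C@]2(O)CC[C@@]1(C)O` gives > 10000 nM, a limit of the assay and not a number. Compound 2 `C[C@@H]1O[C@@]1(C)C(=O)C[C@@H]1[C@@]2(C)[C@@H](O)CCC(C)(C)[C@]2(O)CC[C@@]1(C)O` gives > 10000 nM, which is also only a limit. Going by the values given here, the one measured step is a step that the two limits leave unreadable from compound 1 to compound 2, a change of configuration alone, so it offers no size to carry forward. Compound 3 `C[C@@H]1O[C@@]1(C)C(=O)C[C@H]1[C@](C)(O)CC[C@@]2(O)C(C)(C)CCC[C@]12C` differs from compound 2 by hydrogen in place of hydroxy on a saturated ring carbon. With the limit of > 10000 nM in this assay, at which 2 of the 2 values shown sit, no clear gain in this assay is expected. The expected change is a step that the limit leaves unreadable from compound 2 to compound 3, a rough estimate with no firm direction. For compound 3 the estimated value is 15000 nM, with an expected range of 5000 nM to 50000 nM.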

Compound 3, half-maximal inhibitory concentration: > 10000 nM
Compound 3: a limit, no number (the forecaster's own chance of this, stated with the estimate: 85%); the middle value does not contradict the limit.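

Compound 3 gives > 10000 nM, a limit and not a number. The step between compound 2 and compound 3 therefore cannot be read. The compounds shown leave open whether hydroxy or hydrogen on that ring carbon matters at all in this assay.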